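The source may hold more compounds than are shown below. What is called first, only, known or untested is meant among the compounds shown, and "the series" means these compounds.

Three compounds share one core and differ only in the group on the aromatic carbon. In an assay (Cavia porcellus) for inhibition of Polyunsaturated fatty acid 5-lipoxygenase (Homo sapiens) (a higher number here means a weaker inhibitor, a lower number a stronger inhibitor), compound 1 `NC(=O)N(O)CC1=Cc2cc(OCc3ccccc3)ccc2OC1` gives 440 nM, compound 2 `CCCCCCOc1ccc2c(c1)C=C(CN(O)C(N)=O)CO2` gives 280 nM, and compound 3 `NC(=O)N(O)CC1=Cc2cc(OCC3CCCCC3)ccc2OC1` gives 1360 nM. Compound 3 stands highest of the three numbers: its nearest neighbour is seen in the step of a 3.1-fold higher number from compound 1 to compound 3 (0.49 log units; beyond the scatter), the furthest in a 4.9-fold higher number from compound 2 to compound 3 (0.69 log units; beyond the scatter). Compound 4 `NC(=O)N(O)CC1=Cc2cc(Br)ccc2OC1` carries bromo in place of cyclohexylmethoxy on an aromatic carbon. For the measured compounds named here, none of the measured steps removes the whole group at this position; they only exchange the ring or chain on its carbon, and the step of a 1.6-fold lower number from compound 1 to compound 2 (0.20 log units; within the scatter) shows that such an exchange can stay within the scatter. The expected step is therefore a 1.8-fold higher number from compound 3 to compound 4 (0.26 log units; within the scatter), its size uncertain. In this assay compound 4 is estimated at 2500 nM, within a range from 600 nM to 10000 nM.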

Compound 4, half-maximal inhibitory concentration: 1400 nM
Compound 4: the middle estimate sits 1.8-fold (0.25 log units) above what was measured, within the range that was stated.
By their numbers in this assay, from the lowest: compounds 2 and 1 (each within the scatter of the next); then compounds 3 and 4 (each within the scatter of the next).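

In this assay, replacing the whole cyclohexylmethoxy group with a single bromo atom leaves the number unchanged, with a 1.0-fold higher number from compound 3 to compound 4 (0.01 log units; within the scatter), so at this position that large group offers no gain over bromo. The hexyloxy and benzyloxy groups do improve on bromo, as read in reverse from a 5.0-fold higher number from compound 2 to compound 4 (0.70 log units; beyond the scatter) and a 3.2-fold higher number from compound 1 to compound 4 (0.50 log units; beyond the scatter), so the outcome depends on which group sits on the oxygen. No evidence given here explains this difference. As far as these compounds go, it remains open whether a methoxy group, an amine or a carboxylic acid on this aromatic carbon would track bromo or the hexyloxy and benzyloxy groups.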